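Anilinopyrimidine ureas: aniline swap toward an iodo-methoxy ring

The compounds below may be only part of what the source reports. "The series", "measured", "known", "first", "only" and "open" are said of these compounds alone.

Measured so far:
compound 1, `COc1ccc(Br)cc1Nc1cc(NC(=O)Nc2c(Cl)cccc2Cl)ncn1`: 53%
compound 2, `COc1ccc(OC)c(Nc2cc(NC(=O)Nc3c(Cl)cccc3Cl)ncn2)c1`: 94.1%
compound 3, `CCc1cccc(Nc2cc(NC(=O)Nc3cc(OC)cc(OC)c3)ncn2)c1`: 52.6%

In a functional assay on HCC827 cells (Homo sapiens) for inhibition, read by MTT assay, with a stated time of 48 h, tested at 10 uM (a higher number here means more inhibition at the concentration tested (going by the name of the read-out), a lower number less inhibition), compound 3 gives the lowest of the three numbers, though its gap to compound 1 lies within the scatter; only compound 2 stands clearly apart, well beyond the scatter above both.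

Compound 4, `COc1cc(NC(=O)Nc2cc(Nc3ccc(OC)c(I)c3)ncn2)cc(OC)c1`, differs from compound 3 by 3-iodo-4-methoxyphenyl in place of 3-ethylphenyl on a nitrogen on an aromatic ring. For the measured compounds named here, the one step measured so far, a number 41.1 percentage points higher from compound 1 to compound 2 (beyond the scatter), concerns methoxy in place of bromo on an aromatic carbon, and is large. It bears on the present change only loosely: compound 4 brings a halogen and a methoxy onto the aniline ring at once, whereas the measured step removed a halogen for a methoxy. Going by the values given here, compound 1, the one measured compound carrying a halogen on that ring, sits close to compound 3. Among the compounds with values here, no measured step reports the aniline ring change from an ethylphenyl to a halogen-methoxy ring, so the direction is uncertain.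

A step of a number 2.4 percentage points higher from compound 3 to compound 4 (within the scatter) is expected, in effect within the scatter, with a wide range. Compound 4 is estimated at 55%, between 30% and 80%.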

Compound 4, a percentage reported as inhibition, at one concentration (the size of the read-out at that concentration, not a potency): 61.7%
The estimate for compound 4 lay 6.7 percentage points below the measured number; the range from low to high includes it.
By their numbers in this assay, from the lowest: compounds 3, 1 and 4 (each within the scatter of the next); then compound 2.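

In this assay, replacing 3-ethylphenyl with 3-iodo-4-methoxyphenyl on the nitrogen gives a number 9.1 percentage points higher from compound 3 to compound 4 (within the scatter), the first step shown in which the whole aniline ring changes while the rest of the molecule stays fixed. For the compounds shown here, the earlier step, a number 41.1 percentage points higher from compound 1 to compound 2 (beyond the scatter), exchanged only one group on that ring and carried a different urea partner, so it did not show how this position responds to a full ring exchange. Here an iodo and a methoxy enter together with a larger ring substituent pattern, and the number stays within the scatter of that of compound 3, so this exchange shows no clear change in the inhibition read at the tested concentration; nothing available explains the result.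

The compounds shown leave open how the iodo and the methoxy of the new ring each count on their own, and whether 3-iodo-4-methoxyphenyl would read the same alongside the urea partner of compound 2. They also leave open how an aniline ring carrying a morpholine or a carboxylic acid would read at this position.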